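From Tetrazole to Primary Amide on a Shared Core

A few compounds are considered here, and "the series" means these few. Any claim that something is new, unique, unknown or untested is made for them only; others in the source may bear on it.

Compound 1 `CC(C)C(c1ccc(-c2ccc3cccc(F)c3c2)[nH]c1=O)N1CCCCC1=O`: 6.4 nM
Compound 2 `CC(C)C(Cc1nnn[nH]1)c1ccc(-c2ccc3cccc(F)c3c2)[nH]c1=O`: 34 nM

In an assay on CHO cells for displacement of a labelled ligand from prostaglandin E2 receptor EP3 subtype (Homo sapiens), read by radioligand binding (a higher number here means a weaker inhibitor, a lower number a stronger inhibitor), compound 2 gives the higher of the two numbers and compound 1 the lower, the step of a 5.3-fold higher number from compound 1 to compound 2 (0.73 log units; beyond the scatter) lying beyond the scatter. Compound 3 `CC(C)C(CC(N)=O)c1ccc(-c2ccc3cccc(F)c3c2)[nH]c1=O` differs from compound 2 by carbamoyl in place of 1H-tetrazol-5-yl on a saturated chain carbon, two bonds along the chain from an aromatic carbon. Among the measured compounds shown here, the only measured step, a 5.3-fold higher number from compound 1 to compound 2 (0.73 log units; beyond the scatter), exchanged a different pair of groups and bears on this change only loosely; no step compares a 1H-tetrazol-5-yl group with a carbamoyl group. A modest step of uncertain direction is therefore expected, as a 1.5-fold higher number from compound 2 to compound 3 (0.17 log units; within the scatter). Compound 3 is estimated at 50 nM, within 15 nM to 200 nM.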

Compound 3, inhibition constant: 5 nM
Compound 3: the middle estimate sits 10-fold (1.00 log units) above what was measured, and the stated range ends above it.
By their numbers in this assay, from the lowest: compounds 3 and 1 (each within the scatter of the next); then compound 2.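

In this assay, carbamoyl in place of 1H-tetrazol-5-yl on this saturated chain carbon gives a 6.8-fold lower number from compound 2 to compound 3 (0.83 log units; beyond the scatter), so the higher number of compound 2 goes with the tetrazole and not with the chain that carries it. Carbamoylmethyl and 2-oxopiperidin-1-yl cannot be told apart here, with a 1.3-fold lower number from compound 1 to compound 3 (0.11 log units; within the scatter). Nothing at hand gives a reason for either step. Going by these compounds, whether a carboxylic acid, an amine or a longer chain ending in carbamoyl would fit this position as well as carbamoylmethyl remains open.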